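The source may report more compounds than this note shows. Statements on the series, on what has been measured and on what is new or still open speak of the compounds shown alone.

Working notes on the series, read in a functional assay on cells (T-cell line, Homo sapiens) for inhibition; a lower number here means a stronger inhibitor, a higher number a weaker inhibitor. Three amines sharing one core have been measured: compound 1 (`COc1ccccc1CCCN1CCC(COC(c2ccccc2)c2ccccc2)CC1`) gives 2400 nM, compound 2 (`CCCN1CCC(COC(c2ccccc2)c2ccccc2)CC1`) gives 17800 nM and compound 3 (`CCCCCCN1CCC(COC(c2ccccc2)c2ccccc2)CC1`) gives 5500 nM. Compound 3 therefore stands in the middle of the three numbers. Compound 4 (`c1ccc(C(OCC2CCN(CC3CCc4ccccc4C3)CC2)c2ccccc2)cc1`) is the next to be read, with this change: 1,2,3,4-tetrahydronaphthalen-2-yl in place of pentyl on a saturated chain carbon bound to an amine nitrogen in a ring. In words, 1,2,3,4-tetrahydronaphthalen-2-yl replaces pentyl on a saturated chain carbon bound to an amine nitrogen in a ring.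

Within the data shown here, no measured step makes this exact change. Among the measured compounds shown here, the closest guide is compound 1, the only measured member whose side chain holds an aromatic ring, which gives a 2.3-fold higher number from compound 1 to compound 3 (0.36 log units; beyond the scatter). The other steps, a 3.2-fold lower number from compound 2 to compound 3 (0.51 log units; beyond the scatter) and a 7.4-fold higher number from compound 1 to compound 2 (0.87 log units; beyond the scatter), are also modest. A modest move to a lower number is therefore expected in this assay, of about the size of the step to compound 1. The estimated step is a 2.2-fold lower number from compound 3 to compound 4 (0.34 log units; beyond the scatter). For compound 4 the expected value is 2500 nM, with an estimated range of 800 nM to 7500 nM.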

Compound 4, half-maximal inhibitory concentration: 5600 nM
Estimate against measurement, compound 4: 2.2-fold (0.35 log units) below; measured number inside the range.
By their numbers in this assay, from the lowest: compound 1; then compounds 3 and 4 (each within the scatter of the next); then compound 2.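

In this assay, 1,2,3,4-tetrahydronaphthalen-2-yl and pentyl on a saturated chain carbon bound to an amine nitrogen in a ring give a 1.0-fold higher number from compound 3 to compound 4 (0.01 log units; within the scatter) and so cannot be told apart. An aromatic ring in the side chain is therefore not enough to reach the level of compound 1, as shown by a 2.3-fold higher number from compound 1 to compound 4 (0.37 log units; beyond the scatter) even though the change from ethyl still gives a 3.2-fold lower number from compound 2 to compound 4 (0.50 log units; beyond the scatter) as its result. No available evidence bears on why these side chains read as they do.

The compounds shown leave open whether the methoxy group of compound 1 or its flexible chain to the aromatic ring accounts for its lower number, which a plain 3-phenylpropyl group would test. They also leave open whether a longer chain such as octyl would lower the number further than hexyl does in compound 3.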